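This account rests on a few compounds, and the source may have more. Where it says the series, first, only, none or still open, it means among the compounds named here.

Compound 1 `COc1cc(/C=C/c2cc(OC)c(O)c(OC)c2)cc(OC)c1` in a functional assay on HL-60 cells (Homo sapiens) (on this read-out higher numbers stand for an effect only at larger amounts of compound and lower numbers for an effect already at smaller amounts), gives 79000 nM
Compound 2 `COc1ccc(-c2cccc(-c3cc(OC)cc(OC)c3)c2)cc1` gives > 100000 nM, a limit of the assay and not a number
Compound 3 `COc1cc(OC)cc(-c2ccccc2-c2ccc(O)cc2)c1` gives 10000 nM

Only two of these three results are true numbers, and compound 3 has the lower of them. The other number, from compound 1, is higher by more than the usual scatter of repeated measurements. For the measured compounds named here, compound 3 therefore stands as the only compound here with a reading clearly on the lower side in this assay.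

The next compound, compound 4 `COc1ccc(-c2ccccc2-c2cc(OC)cc(OC)c2)cc1`, has methyl in place of hydrogen on an oxygen on an aromatic ring, so that 4-hydroxyphenyl becomes 4-methoxyphenyl (methyl in place of hydrogen on an oxygen on an aromatic ring). Going by the values given here, no pair of measured compounds shows this change on its own, so any expectation rests on slim ground. Compound 2 also carries 4-methoxyphenyl, and its result is a limit, > 100000 nM. On that single hint, the change is expected to move the reading toward a higher number, though a result within the scatter cannot be ruled out. The expected size is a 3.0-fold higher number from compound 3 to compound 4 (0.48 log units; beyond the scatter) in this assay. For compound 4 the estimated value is 30000 nM, with an expected range from 8000 nM to 100000 nM.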

Compound 4, concentration for half-maximal activity: 15000 nM
Estimate against measurement, compound 4: 2.0-fold (0.30 log units) above; the range from low to high includes it.
By their numbers in this assay, from the lowest: compounds 3 and 4 (each within the scatter of the next); then compound 1. At a limit, above all of these: compound 2.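

For the compounds shown here, the pair gives the first step in this assay that can be read on its own: hydroxy to methoxy, on an oxygen on an aromatic ring, comes out as a 1.5-fold higher number from compound 3 to compound 4 (0.18 log units; within the scatter). At this position, then, the reading does not separate the two groups, and the hydrogen on this oxygen is not needed for a reading of this size in this assay. Compound 4 also shows that 4-methoxyphenyl on this core still gives a true number, so the group alone does not carry a compound to the limit, which remains confined to compound 2: the limit of > 100000 nM in this assay, at which 1 of the 4 values shown sits.

What the compounds shown leave open is how far this position tolerates change, for instance whether an ethyl group or a longer chain on the same oxygen, or an amine or a carboxylic acid in place of the hydroxy group, would keep the reading where it is. From the compounds shown here alone, this is also a single pair on a single core, so whether the same change would behave the same way on the core of compound 1 remains open.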